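A few compounds are considered here, and "the series" means these few. Any claim that something is new, unique, unknown or untested is made for them only; others in the source may bear on it.

Within the data shown here, in an ADME assay on HeLa Rh cells (Homo sapiens) for cytotoxicity, read by microscopy (on this read-out lower numbers stand for higher toxicity in this test and higher numbers for lower toxicity in this test), compound 3 `COc1cc(CC(O)c2ccc(-c3cccc([N+](=O)[O-])c3)cc2)c([N+](=O)[O-])cc1OC` gives 5500 nM, the second highest of the three numbers measured so far. Compound 1 `COc1cc(CC(O)c2ccc(-c3ccc([N+](=O)[O-])cc3)cc2)c([N+](=O)[O-])cc1OC` gives 21000 nM, and the step of a 3.8-fold lower number from compound 1 to compound 3 (0.58 log units; beyond the scatter) lies beyond the scatter. Compound 2 `COc1cc(CC(O)c2ccc(-c3ccc(Cl)cc3)cc2)c([N+](=O)[O-])cc1OC` gives 4100 nM, and the step of a 1.3-fold higher number from compound 2 to compound 3 (0.13 log units; within the scatter) lies within the scatter. Compound 4 `COc1cc(CC(O)c2ccc(-c3ccccc3C#N)cc2)c([N+](=O)[O-])cc1OC` differs from compound 3 in one place: 2-cyanophenyl in place of 3-nitrophenyl on an aromatic carbon. Among the measured compounds shown here, no measured step makes this same exchange. The step of a 5.1-fold lower number from compound 1 to compound 2 (0.71 log units; beyond the scatter) shows that one exchange of the nitro group moved the number modestly, and a 3.8-fold lower number from compound 1 to compound 3 (0.58 log units; beyond the scatter) shows that shifting the nitro group within the ring did likewise, while a 1.3-fold higher number from compound 2 to compound 3 (0.13 log units; within the scatter) shows that two different groups at this position can give numbers within the scatter of each other. Compound 4 is therefore expected to show a step of a 1.1-fold lower number from compound 3 to compound 4 (0.04 log units; within the scatter) in this assay, with no clear direction. For compound 4 the estimated value is 5000 nM, with a range from 2000 nM to 14000 nM.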

Compound 4, half-maximal cytotoxic concentration: 9300 nM
Compound 4: middle estimate off by 1.9-fold (0.27 log units), on the low side; the range from low to high includes it.
By their numbers in this assay, from the lowest: compounds 2, 3 and 4 (each within the scatter of the next, the first and the last beyond it); then compound 1.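

In this assay, a nitrile-bearing ring on this aromatic carbon stays in the range of the other groups: the step of a 1.7-fold higher number from compound 3 to compound 4 (0.23 log units; within the scatter) lies within the scatter, so 2-cyanophenyl and 3-nitrophenyl cannot be told apart here. The other two steps do separate, with a 2.3-fold higher number from compound 2 to compound 4 (0.36 log units; beyond the scatter) and a 2.3-fold lower number from compound 1 to compound 4 (0.35 log units; beyond the scatter) both modest and beyond the scatter, so compound 4 stands clear of both the 4-chlorophenyl and the 4-nitrophenyl compounds, on opposite sides. Nothing available gives a reason for these steps.

The compounds shown leave open how a 4-cyanophenyl or a 2-nitrophenyl group would read, which would separate the effect of the group from the effect of where it sits on the ring. They also leave open whether an amine or a carboxylic acid on this ring would move the number further than any of these steps.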